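From 4-methylphenyl to phenyl on compound 1

This account rests on a few compounds, and the source may have more. Where it says the series, first, only, none or still open, it means among the compounds named here.

In a functional assay on A549 cells (Homo sapiens) for inhibition, read by MTT assay, with a stated time of 72 h (a higher number here means a weaker inhibitor, a lower number a stronger inhibitor), compound 1 (`CC1=NN(c2ccccc2)C(=O)[C@]12C(=O)C=CC[C@H]2c1ccc(C)cc1`) gives 2890 nM and is the strongest of the three measured stereoisomers. Compound 2 (`CC1=NN(c2ccccc2)C(=O)[C@@]12C(=O)C=CC[C@H]2c1ccc(C)cc1`) gives 6090 nM and compound 3 (`CC1=NN(c2ccccc2)C(=O)[C@]12C(=O)C=CC[C@@H]2c1ccc(C)cc1`) gives 8600 nM (the mirror-image pair: a 1.4-fold higher number from compound 2 to compound 3 (0.15 log units; within the scatter)).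

Compound 4 (`CC1=NN(c2ccccc2)C(=O)[C@]12C(=O)C=CC[C@H]2c1ccccc1`) has hydrogen in place of methyl on an aromatic carbon.

The measured steps away from compound 1 (a 2.1-fold higher number from compound 1 to compound 2 (0.32 log units; beyond the scatter) and a 3.0-fold higher number from compound 1 to compound 3 (0.47 log units; beyond the scatter)) are modest and involve configuration only, so neither tests this change directly. They give only a rough scale for the series.

A small rise, not clearly beyond the scatter, is therefore expected in this assay (a 1.3-fold higher number from compound 1 to compound 4 (0.12 log units; within the scatter)). For compound 4 the estimated value is 3800 nM (expected range 1500 nM to 9500 nM).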

Compound 4, half-maximal inhibitory concentration: 8290 nM
Beside the measured number, compound 4's estimate is 2.2-fold (0.34 log units) below it, within the range that was stated.
By their numbers in this assay, from the lowest: compound 1; then compounds 2, 4 and 3 (each within the scatter of the next).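

In this assay, the first change outside configuration gives a 2.9-fold higher number from compound 1 to compound 4 (0.46 log units; beyond the scatter) (modest), so the methyl on the 4-methylphenyl group counts for something at this place. The loss is of a size with a 3.0-fold higher number from compound 1 to compound 3 (0.47 log units; beyond the scatter) and shows that a single methyl on the aromatic carbon can shift the number about as far as a stereocentre does in this series. Nothing given here bears on why this step occurs.

Open, on these data alone, is whether an ethyl group, a methoxy group or a chlorine at this place would hold the number of compound 1. Also open, as far as these compounds go, is whether the same loss appears in the configurations of compound 2 and compound 3.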